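This account rests on a few compounds, and the source may have more. Where it says the series, first, only, none or still open, it means among the compounds named here.

Compound 1 `CC1(C)CC(NC(=O)Nc2ccccc2)c2cc(F)ccc2O1` gives 17100 nM in a functional assay (aorta) with Rattus norvegicus as the target; on this read-out higher numbers stand for an effect only at larger amounts of compound and lower numbers for an effect already at smaller amounts. Compound 2 `CC1(C)CC(NC(=O)Nc2ccccc2)c2cc(Cl)ccc2O1` gives 7800 nM in this assay, and the step of a 2.2-fold lower number from compound 1 to compound 2 (0.34 log units; beyond the scatter) is modest yet beyond the scatter. Compound 3 `COc1ccccc1NC(=O)NC1CC(C)(C)Oc2ccc(F)cc21` reaches only the limit > 10000 nM in this assay. As far as these compounds go, its step that the limit leaves unreadable from compound 1 to compound 3 therefore stays open, in line with the limit of > 10000 nM in this assay, at which 1 of the 3 values shown sits. Compound 4 `COc1ccccc1NC(=O)NC1CC(C)(C)Oc2ccc(Br)cc21` differs from compound 3 by bromo in place of fluoro on an aromatic carbon. Going by the values given here, the only measured step of a like kind, a heavier halogen in place of fluoro at the same position, is a 2.2-fold lower number from compound 1 to compound 2 (0.34 log units; beyond the scatter). A step of similar modest size in the same direction is expected here, an at least 1.1-fold lower number from compound 3 to compound 4 (0.04 log units; that floor lies within the scatter), though the limit for compound 3 leaves the starting point uncertain. Compound 4 is thus estimated at 9000 nM in this assay, with a range from 3000 nM to 30000 nM.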

Compound 4, half-maximal effective concentration: > 10000 nM
Compound 4: only a limit was reported; the forecaster's own chance of this, stated with the estimate: 40%; middle value at least 1.1-fold (0.04 log units) away from the limit.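

No step can be read from compound 3 to compound 4, since both carry only a limit in this assay: the limit of > 10000 nM in this assay, at which 2 of the 4 values shown sit.

The compounds shown leave open whether bromo in place of fluoro shifts the read-out at all in the methoxy compounds.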